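Chloro to trifluoromethyl at the solubility limit

This account rests on a few compounds, and the source may have more. Where it says the series, first, only, none or still open, it means among the compounds named here.

Three compounds share one core and differ in the group on the amide carbonyl. In a physicochemical assay for solubility, at pH 7 (a higher number here means a more soluble compound, a lower number a less soluble compound), compound 1 (`CN1CCC(C(=O)N2Cc3c(NC(=O)c4ccc5ccccc5c4)n[nH]c3C2(C)C)CC1`) gives 219000 nM, a measured number. Compound 2 (`CN1CCC(C(=O)N2Cc3c(NC(=O)c4ccsc4)n[nH]c3C2(C)C)CC1`) gives > 225000 nM, which is a limit of the assay and not a number. Compound 3 (`CN1CCC(C(=O)N2Cc3c(NC(=O)c4ccc(Cl)cc4)n[nH]c3C2(C)C)CC1`) gives > 225000 nM, also a limit and not a number. So compound 3 has no exact position, and the series so far shows (the limit of > 225000 nM in this assay, at which 2 of the 3 values shown sit).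

Compound 4 (`CN1CCC(C(=O)N2Cc3c(NC(=O)c4ccc(C(F)(F)F)cc4)n[nH]c3C2(C)C)CC1`) differs from compound 3 by trifluoromethyl in place of chloro on an aromatic carbon, para to a large group.

Among the measured compounds shown here, three measured steps bear on this change, all of them swaps of the same group. The first is an at least 1.0-fold higher number from compound 1 to compound 2 (0.01 log units; that floor lies within the scatter). The second is an at least 1.0-fold higher number from compound 1 to compound 3 (0.01 log units; that floor lies within the scatter). The third is a step that the two limits leave unreadable from compound 2 to compound 3. These steps give floors or nothing readable, and neither floor lies beyond the scatter, so they offer no support for a change in either direction. No step beyond the scatter is expected in this assay. The estimated step is an at least 1.0-fold lower number from compound 3 to compound 4 (0.00 log units; that floor lies within the scatter). For compound 4 the estimated value is 220000 nM, with an expected range of 130000 nM to 300000 nM.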

Compound 4, solubility: 191000 nM
Compound 4: the middle estimate sits 1.2-fold (0.06 log units) above what was measured; measured number inside the range.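

In this assay the 4-(trifluoromethyl)phenyl group gives a measured number where the 4-chlorophenyl group of compound 3 gives only a limit, and the change reads as an at least 1.1-fold lower number from compound 3 to compound 4 (0.07 log units; that floor lies within the scatter) and so shows no step beyond the scatter. Among the compounds shown here, the comparison with the thiophen-3-yl group of compound 2, also a limit, gives an at least 1.1-fold lower number from compound 2 to compound 4 (0.07 log units; that floor lies within the scatter) and is likewise only a floor, while the one step with a measured number at both ends is a 1.1-fold lower number from compound 1 to compound 4 (0.06 log units; within the scatter) and leaves compound 1 and compound 4 within the scatter of each other. Compound 4 thus adds a second measured number to the series, but the true size of the steps from compound 2 and compound 3 stays unknown, and the step between those two still cannot be read, with compound 2 and compound 3 still at a limit: the limit of > 225000 nM in this assay, at which 2 of the 4 values shown sit.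

Whether any group on this aromatic carbon can move the number beyond the scatter remains open, since the groups shown give only floors within it or a step within it. Going by these compounds, a carboxylic acid, an amine or a longer alkyl chain in place of trifluoromethyl would test that, and the part played by the rest of the shared core also remains open.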